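A few compounds are considered here, and "the series" means these few. Any claim that something is new, unique, unknown or untested is made for them only; others in the source may bear on it.

Measured compounds:
compound 1 `COc1ccc(-c2cc3ccccc3nc2/C=C/C(=O)c2ccc(F)cc2)cc1` – 830 nM
compound 2 `COc1ccc(-c2cc3ccccc3nc2/C=C/C(=O)c2sccc2N)cc1` – > 10000 nM

In a functional assay on MDA-MB-231 cells (Homo sapiens) for antiproliferative activity, read by XTT assay, with a stated time of 72 h (a higher number here means a weaker inhibitor, a lower number a stronger inhibitor), compound 1 gives 830 nM. For compound 2 the assay returns only a limit, > 10000 nM, so no number is known for it. Compound 2 thus sits at the limit of > 10000 nM in this assay, at which 1 of the 2 values shown sits, and its position on the scale is known only as that limit. For the measured compounds named here, the step of an at least 12-fold higher number from compound 1 to compound 2 (1.08 log units; beyond the scatter) is the only measured change and it lies on the carbonyl carbon. Compound 3 `COc1ccc(-c2cc3ccccc3nc2/C=C/C(=O)c2c[nH]c3ccccc23)cc1` introduces (1H-indol-3-yl in place of 3-aminothiophen-2-yl on a carbonyl carbon). Going by the values given here, that same measured step bears on it: changing the group on the carbonyl carbon moved the value a long way, so a further exchange at this position is expected to move it again, and the six-membered aromatic ring of carbon only that enters recalls compound 1 rather than compound 2. Compound 3 is therefore expected to show an at least 3.3-fold lower number from compound 2 to compound 3 (0.52 log units; beyond the scatter), with an estimated value of 3000 nM in the range 700 nM to 15000 nM.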

Compound 3, half-maximal inhibitory concentration: > 10000 nM
Compound 3: no number, only a limit; the forecaster's own chance of this, stated with the estimate: 35%; middle value at least 3.3-fold (0.52 log units) away from the limit.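

With 1H-indol-3-yl on the carbonyl carbon, this assay gives an at least 12-fold higher number from compound 1 to compound 3 (1.08 log units; beyond the scatter), so 3-aminothiophen-2-yl is no longer the only group shown to lose the measurable activity of compound 1. The six-membered aromatic ring of carbon only that 1H-indol-3-yl carries is thus not enough on its own to keep a measurable value at this position. Compound 3 gives only a limit, > 10000 nM, and the step between compound 2 and compound 3 cannot be read, so the two groups cannot be ranked and compound 3 stands where compound 2 stands: the limit of > 10000 nM in this assay, at which 2 of the 3 values shown sit.

Going by these compounds, how far either compound lies beyond that limit remains unknown. Also open, on these data alone, is whether a plain phenyl group or a pyridine ring on the carbonyl carbon would keep a value close to that of compound 1.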